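Where Compound 2 Stands Before a Sulfur-Linked Amine Enters

A few compounds are considered here, and "the series" means these few. Any claim that something is new, unique, unknown or untested is made for them only; others in the source may bear on it.

Two compounds have numbers in an assay on isolated protein for inhibition of Myeloperoxidase (Homo sapiens), read by ELISA, with a stated time of 5 min; on this read-out higher numbers stand for weaker inhibition and lower numbers for stronger inhibition. Compound 1 `NCCCc1c[nH]c2c(F)cccc12` gives 26 nM, and compound 2 `N#CCCCc1c[nH]c2ccc(F)cc12` gives 72 nM, the highest of the two; the gap between these two values lies beyond the scatter. Compound 3 `NCCSCCc1c[nH]c2ccc(F)cc12` carries (2-aminoethyl)sulfanyl in place of cyanomethyl on a saturated chain carbon, two bonds along the chain from an aromatic carbon. Within the data shown here, no step between measured compounds matches this change, so nothing measured sets its size directly. The expected step is a 2.4-fold lower number from compound 2 to compound 3 (0.38 log units; beyond the scatter), a moderate move toward a lower number that is expected to reach beyond the scatter. Compound 3 is therefore estimated at 30 nM, with a range from 10 nM to 100 nM.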

Compound 3, half-maximal inhibitory concentration: 8 nM
The estimate for compound 3 lay 3.8-fold (0.57 log units) above the measured number; the measured number lies below the stated range.
By their numbers in this assay, from the lowest: compound 3; then compound 1; then compound 2.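

In this assay, putting (2-aminoethyl)sulfanyl in place of cyanomethyl on a saturated chain carbon, two bonds along the chain from an aromatic carbon, gives a 9.0-fold lower number from compound 2 to compound 3 (0.95 log units; beyond the scatter) and so lies beyond the scatter. Among these compounds, this is the first measured size for a change at this position, and it shows that the position accepts the sulfur-linked amine with a lower number. Nothing available explains this step. Still open, on these data alone, is whether the sulfur or the terminal amine carries the step; a chain of carbon atoms ending in an amine, or a sulfur-linked chain ending in a carboxylic acid, would separate the two.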